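Bromo in place of chloro on compound 2

The source may hold more compounds than are shown below. What is called first, only, known or untested is meant among the compounds shown, and "the series" means these compounds.

Compound 2 `Cc1oc(-c2c(Cl)cccc2Cl)nc1CN1CCC(C(=O)NCCCN2C[C@H](C)C[C@H](C)C2)CC1` has no exact reading in a physicochemical assay for solubility, in phosphate buffer, measured as kinetic solubility, at pH 7.4; a higher number here means a more soluble compound, a lower number a less soluble compound. Compound 2 gives > 77 ug/mL, which is a limit and not a number. Compound 1 `Cc1ccccc1-c1nc(CN2CCC(C(=O)NCCCN3CCCCC3)CC2)c(C)o1` gives > 65 ug/mL, also a limit. Compound 3 `Cc1ccccc1-c1nc(CN2CCC(C(=O)NCCCN3CCCC(C(C)C)C3)CC2)c(C)o1` gives > 71 ug/mL, again a limit. With only limits on hand, the three compounds cannot be ranked.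

Compound 4 `Cc1oc(-c2c(Cl)cccc2Br)nc1CN1CCC(C(=O)NCCCN2C[C@H](C)C[C@H](C)C2)CC1` differs from compound 2 by one change: bromo in place of chloro on an aromatic carbon. Among the compounds with values here, the only measured step, a step that the two limits leave unreadable from compound 1 to compound 3, is isopropyl in place of hydrogen on a saturated ring carbon. It is a different change, and its size cannot be read from the two limits. Within the data shown here, no measured step covers the bromo for chloro change.

The expectation therefore rests on compound 2 alone, whose > 77 ug/mL is a limit. No step beyond the scatter is expected in this assay, and no direction is expected. The estimated step is a step that the limit leaves unreadable from compound 2 to compound 4. For compound 4 the estimate is 80 ug/mL, with an expected range of 45 ug/mL to 100 ug/mL.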

Compound 4, solubility: > 83 ug/mL
Compound 4 gave a limit, no number; the forecaster's own chance of this, stated with the estimate: 75%; middle value at least 1.0-fold (0.01 log units) from the limit.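

In this assay compound 2 gives > 77 ug/mL, a limit. Compound 4 gives > 83 ug/mL, also a limit, so no step can be read between compound 2 and compound 4. The compounds shown leave open whether bromo in place of chloro on an aromatic carbon changes the reading in this assay at all, and in which direction.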